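The compounds below may be only part of what the source reports. "The series", "measured", "known", "first", "only" and "open" are said of these compounds alone.

Measured so far in the series:
- compound 1, `C=C1/C=C/C(=O)/C(CO)=C\C[C@](C)(CCC=C(C)C)/C=C/[C@H]1OC(=O)C=C(C)C`: 4300 nM
- compound 2, `CC(C)=CCC[C@]1(C)/C=C/[C@@H](OC(=O)C=C(C)C)[C@](C)(O)/C=C/C(=O)/C(CN(C)C)=C\C1`: 820 nM
- compound 3, `CC(C)=CCC[C@]1(C)/C=C/[C@@H](OC(=O)C=C(C)C)[C@](C)(O)/C=C/C(=O)/C(C[Si](c2ccccc2)(c2ccccc2)C(C)(C)C)=C\C1`: 38000 nM

In a functional assay on SMMC-7721 cells (Homo sapiens) for antiproliferative activity, read by MTT assay, with a stated time of 48 h (on this read-out higher numbers stand for weaker inhibition and lower numbers for stronger inhibition), compound 2 gives 820 nM, the lowest number of the three. Compound 1 gives 4300 nM and compound 3 gives 38000 nM; both steps from compound 2 are beyond the scatter, so compound 2 stands as the most potent compound measured here. Within the data shown here, the groups on the double-bonded ring carbon differ across all three, and no single-change pair among the measured compounds is available to read off how much that position is worth.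

Compound 4, `CCN(CC)C(=O)/C1=C/C[C@](C)(CCC=C(C)C)/C=C/[C@@H](OC(=O)C=C(C)C)[C@](C)(O)/C=C/C1=O`, remains to be measured in this assay. It differs from compound 2 in one place: diethylcarbamoyl in place of (dimethylamino)methyl on a double-bonded ring carbon. The (dimethylamino)methyl group is what sets compound 2 apart from compound 1 and compound 3, and swapping it for diethylcarbamoyl removes that group. The expected step from compound 2 to compound 4 is therefore a move to a higher number, a 3.7-fold higher number from compound 2 to compound 4 (0.56 log units; beyond the scatter), beyond the scatter but short of the gap to compound 3. Compound 4 is expected to give about 3000 nM, with a likely range from 800 nM to 12000 nM.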

Compound 4, half-maximal inhibitory concentration: 13800 nM
For compound 4 the middle estimate is 4.6-fold (0.66 log units) below the measured one; measured number outside the range, above it.
By their numbers in this assay, from the lowest: compound 2; then compound 1; then compound 4; then compound 3.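

In this assay the double-bonded ring carbon now has its first single-change reading: diethylcarbamoyl in place of (dimethylamino)methyl gives a 17-fold higher number from compound 2 to compound 4 (1.23 log units; beyond the scatter) with the rest of the core unchanged, so activity in this series is sensitive to the group at this position. The step is large, yet the counts of hydrogen-bond donors and acceptors are the same for the two groups and neither carries a net charge, so these counts do not separate them; the entering group differs in having more heavy atoms, an oxygen and a double bond outside aromatic rings. Nothing measured on these compounds bears on why the change costs this much, so the step stands as an observed difference without an explanation.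

The change alters two features at once, the carbonyl on the ring carbon and the alkyl groups on nitrogen, and the compounds shown cannot apportion the step between them. A dimethylcarbamoyl group and a (diethylamino)methyl group at this position would each change only one of these features, and so would separate the two contributions.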